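The compounds below may be only part of what the source reports. "The series", "measured", "known", "first", "only" and "open" are said of these compounds alone.

In a functional assay on HSC-4 cells (Homo sapiens) for cytotoxicity, with a stated time of 24 h (on this read-out lower numbers stand for higher toxicity in this test and higher numbers for lower toxicity in this test), compound 1 `O=C1/C(=C/c2ccccc2)CCC/C1=C\c1ccccc1[N+](=O)[O-]` gives 3200 nM. Compound 3 `O=C1/C(=C/c2ccc(F)cc2)CCC/C1=C\c1cccc([N+](=O)[O-])c1` gives 2500 nM, which lies within the usual scatter of the value for compound 1, so the two cannot be told apart here. Compound 2 `CN(C)c1ccc(/C=C2\CCC/C(=C\c3ccccc3[N+](=O)[O-])C2=O)cc1` gives > 400000 nM, which is a limit of the assay and not a number.

The next structure to consider is compound 4 `COc1ccc(/C=C2\CCC/C(=C\c3cccc([N+](=O)[O-])c3)C2=O)cc1`. It keeps the rest of compound 3 but carries methoxy in place of fluoro on an aromatic carbon, para to a large group: methoxy in place of fluoro on an aromatic carbon. In other words, 4-fluorophenyl becomes 4-methoxyphenyl.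

Among the compounds with values here, only one measured step offers any guidance, and it is large: an at least 120-fold higher number from compound 1 to compound 2 (2.09 log units; beyond the scatter), with dimethylamino in place of hydrogen on an aromatic carbon. That step differs from the present one in both the group leaving and the group entering, so it is a loose guide to direction and a poor guide to size. A single step also cannot establish a pattern.

The estimated change is a 2.0-fold higher number from compound 3 to compound 4 (0.30 log units; within the scatter), towards a higher number but far smaller than the measured step. In this assay, compound 4 is expected to give about 5000 nM, with an estimated range of 1500 nM to 30000 nM.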

Compound 4, half-maximal cytotoxic concentration: 11000 nM
The estimate for compound 4 lay 2.2-fold (0.34 log units) below the measured number; the measured number falls inside the stated range.
By their numbers in this assay, from the lowest: compounds 3 and 1 (each within the scatter of the next); then compound 4. At a limit, above all of these: compound 2.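

In this assay, methoxy in place of fluoro on an aromatic carbon, para to a large group, gives a 4.4-fold higher number from compound 3 to compound 4 (0.64 log units; beyond the scatter), so this position responds to a change of group by more than the usual scatter, here towards lower toxicity in this test. Within the data shown here, this step has a true number at both ends, whereas the only earlier step, an at least 120-fold higher number from compound 1 to compound 2 (2.09 log units; beyond the scatter), ends at a limit and so gives direction without an exact size; both steps point towards a higher number, though two steps from different starting compounds do not make a pattern. No measurement shown here accounts for the rise from fluoro to methoxy.

Going by these compounds, whether a hydroxy group, an ethoxy group or a plain methyl group at this place would shift the number as methoxy does remains open, and so does the question of how a smaller amine, such as a simple amino group, would compare with the dimethylamino group of compound 2. On these data alone, it is also open whether methoxy on the phenyl ring of compound 1 would produce a step of similar size.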